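Changing the Acyl Aryl Group from Compound 3 to Compound 4

This account rests on a few compounds, and the source may have more. Where it says the series, first, only, none or still open, it means among the compounds named here.

Compound 1, `CNc1nc(C)c(C(=O)N/N=C/c2cccc(C(F)(F)F)c2)s1`, in a functional assay on MCF7 cells (Homo sapiens) for inhibition, read by MTT assay, with a stated time of 72 h (a higher number here means a weaker inhibitor, a lower number a stronger inhibitor), reaches only the limit > 100 ug/mL, not a number.
Compound 2, `CN(C(=O)NC(=O)c1cccc(C(F)(F)F)c1)c1nc(C(F)(F)F)c(C(=O)N/N=C/c2ccc(C(F)(F)F)cc2)s1`, in this assay gives 6.5 ug/mL.
Compound 3, `CN(C(=O)NC(=O)c1cccc(C(F)(F)F)c1)c1nc(C(F)(F)F)c(C(=O)N/N=C/c2ccccc2C(F)(F)F)s1`, in this assay gives 7.69 ug/mL.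

Compound 3 holds the higher of the two numbers, yet the gap a 1.2-fold higher number from compound 2 to compound 3 (0.07 log units; within the scatter) lies within the scatter, so neither compound counts as the stronger inhibitor. Compound 4, `CN(C(=O)NC(=O)c1c(F)cccc1F)c1nc(C(F)(F)F)c(C(=O)N/N=C/c2ccccc2C(F)(F)F)s1`, differs from compound 3 by 2,6-difluorophenyl in place of 3-(trifluoromethyl)phenyl on a carbonyl carbon. Within the data shown here, no measured step touches this group: the single measured step, a 1.2-fold higher number from compound 2 to compound 3 (0.07 log units; within the scatter), alters a different ring and stayed within the scatter. Lacking any bearing step, the estimate for compound 4 is a change of a 1.0-fold higher number from compound 3 to compound 4 (0.02 log units; within the scatter), no larger than the scatter. Compound 4 is therefore expected to give about 8 ug/mL, most likely between 3.5 ug/mL and 18 ug/mL.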

Compound 4, half-maximal inhibitory concentration: 20.4 ug/mL
For compound 4 the middle estimate is 2.6-fold (0.41 log units) below the measured one, outside the stated range (above it).
By their numbers in this assay, from the lowest: compounds 2 and 3 (each within the scatter of the next); then compound 4. At a limit, above all of these: compound 1.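

In this assay, 2,6-difluorophenyl in place of 3-(trifluoromethyl)phenyl on the carbonyl carbon gives a 2.7-fold higher number from compound 3 to compound 4 (0.42 log units; beyond the scatter), so this swap weakens inhibition. It is the first change shown at this position, and the only earlier step, a 1.2-fold higher number from compound 2 to compound 3 (0.07 log units; within the scatter), altered a different ring. Nothing measured here accounts for the loss.

This one swap changes both the ring's fluorine-bearing groups and where they sit, and the two effects cannot be separated. From the compounds shown here alone, how a plain phenyl, or a ring carrying an amine or a carboxylic acid, would behave on this carbonyl remains open.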